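Oral exposure in mice: swapping an aryl group

A few compounds are considered here, and "the series" means these few. Any claim that something is new, unique, unknown or untested is made for them only; others in the source may bear on it.

Measured so far, in an ADME assay on the whole organism (Mus musculus, strain CD-1) for pharmacokinetics, at a dose of 10 mg/kg by the oral route; a higher number here means more compound in the circulation at the dose given, a lower number less compound in the circulation:
Compound 1 `CCOc1cc([C@](O)(CCN(C)C)[C@@H](c2cc3cc(Br)ccc3nc2OC)c2cccc(OC)c2F)cc(OC)n1` gives 4000 ng.h/mL.
Compound 2 `CCOc1cc([C@](O)(CCN(C)C)[C@@H](c2cc3cc(Br)ccc3nc2OC)c2ccnc(OC)c2OC)cc(OC)n1` gives 12700 ng.h/mL.
Compound 3 `COc1cccc([C@H](c2cc3cc(Br)ccc3nc2OC)[C@@](O)(CCN(C)C)c2cc(SC)nc(SC)c2)c1F` gives 8400 ng.h/mL.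

Compounds 1 and 2 share a core and differ in one group: 2,3-dimethoxypyridin-4-yl in place of 2-fluoro-3-methoxyphenyl on a saturated chain carbon bound to an aromatic carbon and a saturated chain carbon. This change gave a 3.2-fold higher number from compound 1 to compound 2 (0.50 log units; beyond the scatter). Compounds 1 and 3 differ in their cores instead: a group of 10 heavy atoms (7 carbon, 1 nitrogen, 2 sulfur; one six-membered aromatic ring with 1 hetero atom) in place of a group of 11 heavy atoms (8 carbon, 1 nitrogen, 2 oxygen; one six-membered aromatic ring with 1 hetero atom), on a saturated chain carbon bound to an oxygen on a saturated carbon and two saturated chain carbons, which gave a 2.1-fold higher number from compound 1 to compound 3 (0.32 log units; beyond the scatter). Compounds 2 and 3 stand within the usual scatter of each other, so nothing can be said about their order.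

Compound 4 `COc1nc2ccc(Br)cc2cc1[C@@H](c1ccnc(OC)c1OC)[C@@](O)(CCN(C)C)c1cc(SC)nc(SC)c1` has not been measured yet. It differs from compound 3 in exactly the way compound 2 differs from compound 1: 2,3-dimethoxypyridin-4-yl in place of 2-fluoro-3-methoxyphenyl on a saturated chain carbon bound to an aromatic carbon and a saturated chain carbon, at the same place. Among the measured compounds shown here, the only guide to what this change does to exposure is the single measured step, so the expectation for compound 4 rests on carrying that step over to compound 3, with some allowance because compound 3 gives 8400 ng.h/mL from a core that differs from the core of compound 1, and that core may respond differently. Compound 4 is therefore expected to give a 2.6-fold higher number from compound 3 to compound 4 (0.42 log units; beyond the scatter). For compound 4 the estimate is 22000 ng.h/mL, expected to fall between 10000 ng.h/mL and 45000 ng.h/mL.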

Compound 4, area under the concentration-time curve: 3900 ng.h/mL
Compound 4: middle estimate off by 5.6-fold (0.75 log units), on the high side; the measured number lies below the stated range.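

In this assay, 2,3-dimethoxypyridin-4-yl in place of 2-fluoro-3-methoxyphenyl gave a 2.2-fold lower number from compound 3 to compound 4 (0.33 log units; beyond the scatter), so the swap that raised the number on the core of compound 1 lowered it on the core of compound 3: the same change on two cores in this assay, a 3.2-fold higher number (0.50 log units; beyond the scatter) from compound 1 to compound 2 and a 2.2-fold lower number (0.33 log units; beyond the scatter) from compound 3 to compound 4, 6.8-fold (0.83 log units) apart, beyond the scatter of two such steps. Read the other way, the sulfur-bearing group in place of the oxygen-bearing one gave a 3.3-fold lower number from compound 2 to compound 4 (0.51 log units; beyond the scatter), the opposite direction to its step with 2-fluoro-3-methoxyphenyl: the same change on two cores in this assay, a 2.1-fold higher number (0.32 log units; beyond the scatter) from compound 1 to compound 3 and a 3.3-fold lower number (0.51 log units; beyond the scatter) from compound 2 to compound 4, 6.8-fold (0.83 log units) apart, beyond the scatter of two such steps. The two changes therefore do not simply add up, and a step measured on one core did not carry over to the other here, but this rests on a single pair of cores and a single exposure read-out, which does not show why the direction reversed.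

Still open, on these data alone, is whether another core would behave like the core of compound 1 or that of compound 3. It is also unknown how a group such as an amine or a chlorine on the aromatic ring would fare in the same swap.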